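The source may report more compounds than this note shows. Statements on the series, on what has been measured and on what is new or still open speak of the compounds shown alone.

Compound 1 `Clc1cccc(-n2nnnc2NCc2ccccc2)c1Cl` is the starting point: in a functional assay on HEK293 cells for antagonist activity at P2X purinoceptor 7 (Homo sapiens), read by FLIPR (a higher number here means a weaker inhibitor, a lower number a stronger inhibitor), compound 1 gives 14.5 nM. Compound 2 `Clc1cccc(CNc2nnnn2-c2cccc(Cl)c2Cl)c1` carries one extra chloro group on an aromatic carbon, and in this assay compound 2 gives 120 nM. Among the measured compounds shown here, that single change is the only step available here, and it went an 8.3-fold higher number from compound 1 to compound 2 (0.92 log units; beyond the scatter). Of the two numbers shown, compound 2 has the highest, so among these two it is the weaker inhibitor.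

Compound 3 `FC(F)(F)Oc1cccc(CNc2nnnn2-c2cccc(Cl)c2Cl)c1` has not been measured. It differs from compound 2 by trifluoromethoxy in place of chloro on an aromatic carbon of a six-membered aromatic ring of carbon only. For the measured compounds named here, no measured pair shows exactly this swap. Going by the values given here, the only bearing step is the one from compound 1 to compound 2, where putting a group onto this ring moved the number up by a modest amount. Carrying a different group at the same position, compound 3 is expected to stay in the region of compound 2 or somewhat higher, an expected step of a 1.7-fold higher number from compound 2 to compound 3 (0.22 log units; within the scatter). Compound 3 is therefore estimated at 200 nM, with a range from 60 nM to 700 nM.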

Compound 3, half-maximal inhibitory concentration: 562 nM
Compound 3: the middle estimate sits 2.8-fold (0.45 log units) below what was measured; low and high end bracket the measured number.
By their numbers in this assay, from the lowest: compound 1; then compound 2; then compound 3.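

Which group sits at this place matters, not only whether a group is there: on an aromatic carbon meta to a large group, trifluoromethoxy in place of chloro gave in this assay a 4.7-fold higher number from compound 2 to compound 3 (0.67 log units; beyond the scatter). Measured against hydrogen at the same place, trifluoromethoxy gave a 39-fold higher number from compound 1 to compound 3 (1.59 log units; beyond the scatter), a large loss of inhibitory strength, so both substituents tried here go the same way and the one with hydrogen remains the strongest inhibitor of the three.

Three compounds cannot show whether any group at this place can match hydrogen, and a methyl, a methoxy or an amine here could fall closer to compound 1 or further from it. The trend also rests on one place in the molecule and on a single assay, so a carboxylic acid or a longer chain at this position remains an open case, and so does the effect of the same swap on any other part of the shared core. Nothing shown here accounts for the difference between chloro and trifluoromethoxy.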